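Replacing 4-Fluorophenyl with 4-Chloro-3-nitrophenyl on the Shared Core

This account rests on a few compounds, and the source may have more. Where it says the series, first, only, none or still open, it means among the compounds named here.

Compound 1 `COc1cc(C2=NN(C(C)=O)C(c3cc(Cl)cc(Cl)c3)O2)cc(OC)c1OC` and compound 2 `COc1cc(C2=NN(C(C)=O)C(c3ccc(F)cc3)O2)cc(OC)c1OC` share one core and differ only in the aryl group on a saturated ring carbon. For the measured compounds named here, in a functional assay on PC-3 cells (Homo sapiens) for antiproliferative activity, read by MTT assay, tested at 1 uM (a lower number here means a weaker effect, a higher number a stronger effect of the compound at the concentration tested), compound 1 gives 52.7%, whereas compound 2 gives 0%, the lowest of the two numbers known so far; the step of a number 52.7 percentage points lower from compound 1 to compound 2 (beyond the scatter) separates them. Compound 3 `COc1cc(C2=NN(C(C)=O)C(c3ccc(Cl)c([N+](=O)[O-])c3)O2)cc(OC)c1OC` has not yet been measured. The change from compound 2 is 4-chloro-3-nitrophenyl in place of 4-fluorophenyl on a saturated ring carbon. Going by the values given here, only one measured step bears on it: swapping a 3,5-dichlorophenyl for a 4-fluorophenyl lowered the read-out by a number 52.7 percentage points lower from compound 1 to compound 2 (beyond the scatter). Since compound 3 again carries a chlorine-bearing aryl, with a nitro group as well, an upward step a number 30 percentage points higher from compound 2 to compound 3 (beyond the scatter) is expected, though on a single comparison its size is uncertain. Compound 3 is therefore estimated at 30%, in a range from 5% to 60%.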

Compound 3, a percentage reported as inhibition, at one concentration (the size of the read-out at that concentration, not a potency): 43.3%
Compound 3: middle estimate off by 13.3 percentage points, on the low side; the measured number falls inside the stated range.
By their numbers in this assay, from the lowest: compound 2; then compounds 3 and 1 (each within the scatter of the next).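

With 4-chloro-3-nitrophenyl on the saturated ring carbon, the read-out in this assay moves well clear of the 4-fluorophenyl compound, by the step of a number 43.3 percentage points higher from compound 2 to compound 3 (beyond the scatter) and so beyond the scatter. For the compounds shown here, the 3,5-dichlorophenyl group is therefore not the only aryl group that gives a clear response at this position, and the step of a number 9.4 percentage points lower from compound 1 to compound 3 (within the scatter) leaves those two groups level even though their rings carry different groups. Among these compounds, both chlorine-bearing aryl groups give a response and the fluorine-bearing one gives none, but nothing available explains this difference.

From the compounds shown here alone, it remains open whether the chlorine, the nitro group or the two together account for the response. Going by these compounds, how a plain phenyl, or a phenyl carrying an amine or a carboxylic acid, would read at this position also remains unknown.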